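Methyl in place of hydrogen on an aromatic nitrogen

This account rests on a few compounds, and the source may have more. Where it says the series, first, only, none or still open, it means among the compounds named here.

Measured so far:
compound 1 `Nc1n[nH]c2cc(-c3cccs3)[nH]c(=O)c12`, 59%
compound 2 `CC(C)(C)c1cc2[nH]nc(N)c2c(=O)[nH]1`, 21%
compound 3 `Cc1cc2[nH]nc(N)c2c(N2CCCCC2)n1`, 33%

In an assay on isolated protein for inhibition of serine/threonine-protein kinase Chk2 (Homo sapiens), read by mobility shift assay, tested at 30 uM (a higher number here means more inhibition at the concentration tested (going by the name of the read-out), a lower number less inhibition), compound 3 stands second of the three measured numbers, beyond the scatter below compound 1 and beyond the scatter above compound 2. Compound 4 `Cc1cc2c(c(N)nn2C)c(N2CCCCC2)n1` differs from compound 3 by methyl in place of hydrogen on an aromatic nitrogen. The one measured step, a number 38 percentage points lower from compound 1 to compound 2 (beyond the scatter), concerns a group on an aromatic carbon and does not bear on a change at an aromatic nitrogen, so no shown step informs this one. Going by the values given here, with no direct precedent, the expectation for compound 4 is set wide around a modest loss, so that compound 4 is expected to give 20%, between 0% and 45%. That estimated step, a number 13 percentage points lower from compound 3 to compound 4 (beyond the scatter), is expected but uncertain.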

Compound 4, a percentage reported as inhibition, at one concentration (the size of the read-out at that concentration, not a potency): 4%
Estimate against measurement, compound 4: 16 percentage points above; the measured number falls inside the stated range.
By their numbers in this assay, from the lowest: compound 4; then compound 2; then compound 3; then compound 1.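

In this assay, methyl in place of hydrogen on the aromatic nitrogen gives a number 29 percentage points lower from compound 3 to compound 4 (beyond the scatter), the only step shown at a ring nitrogen rather than on an aromatic carbon. With the rest of the structure unchanged, this position therefore does not take a methyl without a loss beyond the scatter. Nothing available explains that loss.

From the compounds shown here alone, whether an ethyl group or a longer chain on this nitrogen would behave like methyl remains open. So does whether methyl here would cost as much in compound 1, which carries thiophen-2-yl.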